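Clearance in Rat Liver Microsomes Across Three Pyridine Substituents

The source may report more compounds than this note shows. Statements on the series, on what has been measured and on what is new or still open speak of the compounds shown alone.

Measured so far in an in vitro ADME assay on microsomes from liver (Rattus norvegicus) for pharmacokinetics; on this read-out higher numbers stand for fast clearance and lower numbers for slow clearance:
- compound 1, `Nc1nc(C(F)(F)F)cc2c1[nH]c(=O)n2Cc1ccc(NCCN2CCCC2)nc1`, reports a limit of < 8.5 mL.min-1.g-1 and no number.
- compound 2, `Nc1nc(C(F)(F)F)cc2c1[nH]c(=O)n2Cc1ccc(NCc2ccccc2)nc1`, gives 16 mL.min-1.g-1.

Among the compounds with values here, compound 2 therefore stands as the only numbered value in this assay; the other result is a limit (the limit of < 8.5 mL.min-1.g-1 in this assay, at which 1 of the 2 values shown sits). Within the data shown here, the one measured step, an at least 1.8-fold higher number from compound 1 to compound 2 (0.27 log units; that floor lies within the scatter), runs from that limit to the number of compound 2, and its floor sits within the scatter.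

Compound 3 is `CN1CCN(c2ccc(Cn3c(=O)[nH]c4c(N)nc(C(F)(F)F)cc43)cn2)CC1`. Relative to compound 2 the change is 4-methylpiperazin-1-yl in place of benzylamino on an aromatic carbon. This change takes out the aromatic carbon-only ring that came in with the step from compound 1 to compound 2 and brings in a six-membered non-aromatic ring with 2 hetero atoms, so the step bearing on it is an at least 1.8-fold higher number from compound 1 to compound 2 (0.27 log units; that floor lies within the scatter), read in reverse. Compound 3 is expected to move down in this assay by a 2.0-fold lower number from compound 2 to compound 3 (0.30 log units; within the scatter), likely back toward the limit. The estimate for compound 3 is 8 mL.min-1.g-1, within 4 mL.min-1.g-1 to 16 mL.min-1.g-1.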

Compound 3, intrinsic clearance in microsomes: 46 mL.min-1.g-1
Beside the measured number, compound 3's estimate is 5.8-fold (0.76 log units) below it; measured number above the stated range.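

Within the data shown here, the step of a 2.9-fold higher number from compound 2 to compound 3 (0.46 log units; beyond the scatter) is the first change at this aromatic carbon, next to the ring nitrogen, that clears the scatter in this assay. The saturated ring with two nitrogens does not keep the number low here, and the two nitrogen-bearing groups, (2-(pyrrolidin-1-yl)ethyl)amino and 4-methylpiperazin-1-yl, lie well apart on this read-out: an at least 5.4-fold higher number from compound 1 to compound 3 (0.73 log units; beyond the scatter). That second step is only a floor, as compound 1 reports a limit and not a number: the limit of < 8.5 mL.min-1.g-1 in this assay, at which 1 of the 3 values shown sits.

The compounds shown leave open whether the rise goes with the loss of the hydrogen-bond donor on the linking nitrogen or with the ring itself, a question that a piperazin-1-yl group without the methyl, a morpholin-4-yl group, or a 4-methylpiperazine held on an amino linker could separate. They also do not show which part of compound 3 accounts for its number, so the change can be described here but not explained.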